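Hydroxy in place of a hydroxyphenyl: a cell-growth comparison

A few compounds are considered here, and "the series" means these few. Any claim that something is new, unique, unknown or untested is made for them only; others in the source may bear on it.

Measured compounds:
compound 1 `CC1(C)OC(=O)C2(C(=O)O1)[C@@H](c1ccc(-c3ccc(O)cc3)cc1)CC(=O)C[C@H]2c1ccccc1`, 8000 nM
compound 2 `CC1(C)OC(=O)C2(C(=O)O1)[C@@H](c1ccc(-c3ccc(-c4ccc(O)cc4)cc3)cc1)CC(=O)C[C@H]2c1ccccc1`, 16000 nM
compound 3 `Oc1ccc(-c2ccc(-c3cc(O)cc(O)c3)cc2)cc1`, 7000 nM

All three were tested in a functional assay on HL-60 cells (Homo sapiens) for antiproliferative activity, read by trypan blue exclusion, with a stated time of 48 h; on this read-out lower numbers stand for stronger inhibition and higher numbers for weaker inhibition. Compound 2 and compound 1 share a core and differ in one place: hydroxy in place of 4-hydroxyphenyl on an aromatic carbon. That step was a 2.0-fold lower number from compound 2 to compound 1 (0.30 log units; within the scatter). Compound 3 has a different core; the difference between the two cores is not broken down here. In this assay compound 3 gives 7000 nM, a number within the scatter of that of compound 1 and beyond the scatter of that of compound 2.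

Compound 4 `Oc1ccc(-c2cc(O)cc(O)c2)cc1` is not yet measured. It differs from compound 3 by hydroxy in place of 4-hydroxyphenyl on an aromatic carbon. This is the same kind of change as that from compound 2 to compound 1, not the same: in compound 3 the place is para to a group of 8 heavy atoms, whereas in compound 2 it is para to a large group. Since the earlier step was within the scatter, the step is expected to be small, a 1.4-fold lower number from compound 3 to compound 4 (0.15 log units; within the scatter). Compound 4 is therefore estimated at 5000 nM, between 1500 nM and 16000 nM.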

Compound 4, half-maximal inhibitory concentration: > 80000 nM
Compound 4 gave a limit, no number; the forecaster's own chance of this, stated with the estimate: 10%; at least 16-fold (1.20 log units) between middle value and limit.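

In this assay compound 4 gave > 80000 nM, which is a limit of the assay and not a number. Even so, the step can be read, an at least 11-fold higher number from compound 3 to compound 4 (1.05 log units; beyond the scatter), and it does not match the earlier step of the same kind: the same change on two cores in this assay, a 2.0-fold lower number (0.30 log units; within the scatter) from compound 2 to compound 1 and an at least 11-fold higher number (1.05 log units; beyond the scatter) from compound 3 to compound 4, at least 22-fold (1.35 log units) apart, beyond the scatter of two such steps. This shows that the effect of putting hydroxy in place of 4-hydroxyphenyl did not carry over from one core to the other, so the small step on the first core was a poor guide to the second, but two cores cannot show why the steps differ, and the full size of the new step stays unknown.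

The compounds shown leave open what other groups in this place, such as an amine, a carboxylic acid or a methoxy group, would give on the core of compound 3. They also leave open which of the two steps the same change would resemble on a further core.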